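Benzoyl ring substituent: fluoro replaced by methoxy

The source may hold more compounds than are shown below. What is called first, only, known or untested is meant among the compounds shown, and "the series" means these compounds.

Measured so far in a functional assay on DLD-1 cells (Homo sapiens); a lower number here means a stronger inhibitor, a higher number a weaker inhibitor:
compound 1 `N#Cc1ccc(Cn2cncc2CN(C(=O)c2ccccc2)c2ccc(N3CCN(C(=O)c4ccc(Cl)s4)CC3)cc2)cc1` gives 3 nM
compound 2 `N#Cc1ccc(Cn2cncc2CN(c2ccc(N3CCN(C(=O)c4ccc(Cl)s4)CC3)cc2)S(=O)(=O)c2ccccc2)cc1` gives 200 nM
compound 3 `N#Cc1ccc(Cn2cncc2CN(C(=O)c2cccc(F)c2)c2ccc(N3CCN(C(=O)c4ccc(Cl)s4)CC3)cc2)cc1` gives 6 nM

Compound 3 stands second highest of the three numbers. The step of a 2.0-fold higher number from compound 1 to compound 3 (0.30 log units; within the scatter) is within the scatter, so compound 1 and compound 3 cannot be ordered against each other; the step of a 33-fold lower number from compound 2 to compound 3 (1.52 log units; beyond the scatter) is large and places compound 2 well apart from both.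

Compound 4 `COc1cccc(C(=O)N(Cc2cncn2Cc2ccc(C#N)cc2)c2ccc(N3CCN(C(=O)c4ccc(Cl)s4)CC3)cc2)c1` differs from compound 3 by methoxy in place of fluoro on an aromatic carbon. For the measured compounds named here, the only measured step that touches the same ring is a 2.0-fold higher number from compound 1 to compound 3 (0.30 log units; within the scatter), which lies within the scatter: one substitution at that position on the benzoyl ring left the number essentially unchanged. The large steps of a 67-fold higher number from compound 1 to compound 2 (1.82 log units; beyond the scatter) and a 33-fold lower number from compound 2 to compound 3 (1.52 log units; beyond the scatter) concern the exchange of benzoyl for phenylsulfonyl on the aryl nitrogen, not a substituent on the benzoyl ring, and so do not bear directly on this change. No methoxy on that ring has been measured, so the direction is open. The expectation for compound 4 in this assay is therefore no step beyond the scatter, estimated as 8 nM with a range of 3 nM to 25 nM, that is a 1.3-fold higher number from compound 3 to compound 4 (0.12 log units; within the scatter) relative to compound 3.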

Compound 4, half-maximal inhibitory concentration: 7 nM
For compound 4 the middle estimate is 1.1-fold (0.06 log units) above the measured one; measured number inside the range.
By their numbers in this assay, from the lowest: compounds 1, 3 and 4 (each within the scatter of the next, the first and the last beyond it); then compound 2.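

In this assay, the exchange of fluoro for methoxy on this aromatic carbon, which brings in a hydrogen-bond acceptor, gives no separation (a 1.2-fold higher number from compound 3 to compound 4 (0.07 log units; within the scatter)), so compound 3 and compound 4 cannot be ordered against each other. Set against the benzoyl without a substituent, however, methoxy gives the only step at this position that lies beyond the scatter (a 2.3-fold higher number from compound 1 to compound 4 (0.37 log units; beyond the scatter)); it is modest, and the fluoro step from compound 1 to compound 3 does not share that standing. The large gap to the phenylsulfonyl compound also holds with methoxy on the ring (a 29-fold lower number from compound 2 to compound 4 (1.46 log units; beyond the scatter)), as it did with fluoro, while no independent measurement on these compounds offers an explanation for any of these steps.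

Open, going by these compounds, is whether this place on the ring stays as accommodating with an amine or a carboxylic acid, or with a longer chain such as ethoxy or propoxy in place of methoxy. Also open, on these data alone, is whether a larger group here would widen the modest step from the unsubstituted benzoyl or leave the number within the scatter of compound 3 and compound 4.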